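The source may hold more compounds than are shown below. What is called first, only, known or untested is meant among the compounds shown, and "the series" means these compounds.

Of the compounds shown here, two that share a core have so far been tested in a functional assay on MCF7 cells (Homo sapiens) for antiproliferative activity; on this read-out higher numbers stand for weaker inhibition and lower numbers for stronger inhibition. Compound 1 `O=[N+]([O-])c1ccc(S(=O)(=O)N2CC(n3cnc4ncnc(O)c43)OCc3ccccc32)cc1` reaches only the limit of that assay, > 100000 nM. Among the measured compounds shown here, compound 2 `O=c1ccn(C2CN(S(=O)(=O)c3ccc([N+](=O)[O-])cc3)c3ccccc3CO2)c(=O)[nH]1` gives 39800 nM in this assay, the only real number among the two. The step of an at least 2.5-fold lower number from compound 1 to compound 2 (0.40 log units; beyond the scatter) therefore favours compound 2. Compound 3 `O=[N+]([O-])c1ccc(S(=O)(=O)N2CC(n3cnc4ncnc(Cl)c43)OCc3ccccc32)cc1` carries a group of 10 heavy atoms (5 carbon, 4 nitrogen, 1 chlorine; one five-membered aromatic ring with 2 hetero atoms, one six-membered aromatic ring with 2 hetero atoms) in place of a group of 8 heavy atoms (4 carbon, 2 nitrogen, 2 oxygen; one six-membered aromatic ring with 2 hetero atoms), on a saturated ring carbon. For the measured compounds named here, this largely undoes that earlier step, with the entering group differing from the one in compound 1 only by its chlorine, so a rise in the number is expected, a 2.3-fold higher number from compound 2 to compound 3 (0.35 log units; beyond the scatter). For compound 3 the estimate is 90000 nM, within 30000 nM to 300000 nM.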

Compound 3, half-maximal inhibitory concentration: 1220 nM
For compound 3 the middle estimate is 74-fold (1.87 log units) above the measured one; the measured number lies below the stated range.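

The larger entering group on this saturated ring carbon can clearly outdo the smaller one, with a 33-fold lower number from compound 2 to compound 3 (1.51 log units; beyond the scatter). Within that larger group, one swap of chloro in place of hydroxy on an aromatic carbon decides the outcome, with an at least 81-fold lower number from compound 1 to compound 3 (1.91 log units; beyond the scatter). Compound 1 stands only at a limit of the assay: the limit of > 100000 nM in this assay, at which 1 of the 3 values shown sits.

From the compounds shown here alone, what an amine or a methoxy group would give on that aromatic carbon stays open. The compounds shown therefore cannot tell whether chloro is specially favourable or hydroxy is simply unfavourable there.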